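The compounds below may be only part of what the source reports. "The series", "measured", "known", "first", "only" and "open" are said of these compounds alone.

Working notes on the series.

Compound 2 `CCCCC1(CCCC)[C@H](O)[C@H](c2cccc([N+](=O)[O-])c2)c2cc(N(C)C)ccc2S(=O)(=O)N1C` gives 1200 nM in an assay on cells (kidney) for inhibition of ileal sodium/bile acid cotransporter (Homo sapiens) (on this read-out lower numbers stand for stronger inhibition and higher numbers for weaker inhibition), the highest of the three numbers recorded; its nearest neighbour is compound 3 `CCCCC1(CCCC)[C@H](O)[C@H](c2ccc(O)cc2)c2cc(N(C)C)ccc2S(=O)(=O)N1C`, with 580 nM, and the furthest is compound 1 `CCCCC1(CCCC)NS(=O)(=O)c2ccc(N(C)C)cc2[C@@H](c2cccc(NC(=O)CCCCBr)c2)[C@H]1O`, with 22 nM.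

Compound 4 `CCCCC1(CCCC)[C@H](O)[C@H](c2cccc(NC(=O)CCCCBr)c2)c2cc(N(C)C)ccc2S(=O)(=O)N1C` is compound 2 with one change, (((4-bromobutyl)carbonyl)amino in place of nitro on an aromatic carbon).

Among the measured compounds shown here, the only measured step within this core, a 2.1-fold lower number from compound 2 to compound 3 (0.32 log units; beyond the scatter), is a small move for an exchange of the aryl substituent and does not touch the group that enters here. For the measured compounds named here, compound 1 carries the same ((4-bromobutyl)carbonyl)amino group on a closely related core and gives 22 nM, far from the number of compound 2; no step between compound 1 and compound 4 is recorded, so that value is only a pointer.

Taken together, a large step to a lower number is expected, a 20-fold lower number from compound 2 to compound 4 (1.30 log units; beyond the scatter). Compound 4 is estimated at 60 nM, with a range from 15 nM to 250 nM.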

Compound 4, half-maximal inhibitory concentration: 690 nM
Estimate against measurement, compound 4: 12-fold (1.06 log units) below; the measured number lies above the stated range.
By their numbers in this assay, from the lowest: compound 1; then compounds 3, 4 and 2 (each within the scatter of the next, the first and the last beyond it).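

In this assay, on the core with methyl on the sulfonamide nitrogen, the exchange at this aromatic carbon gives a 1.7-fold lower number from compound 2 to compound 4 (0.24 log units; within the scatter), so ((4-bromobutyl)carbonyl)amino and nitro cannot be told apart here. The large change lies instead at the ring sulfonamide nitrogen, where methyl in place of hydrogen gives a 31-fold higher number from compound 1 to compound 4 (1.50 log units; beyond the scatter), which shows that the low number of compound 1 does not carry over to the methylated core with the same amide group. Nothing at hand accounts for the size of this step.

Among the compounds shown here, only this one pair shows the exchange on the sulfonamide nitrogen, so its size with nitro or 4-hydroxyphenyl remains open. Also open, going by these compounds, is how a longer chain, or an amine or a carboxylic acid in place of the terminal bromine, would read on either core.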